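A few compounds are considered here, and "the series" means these few. Any claim that something is new, unique, unknown or untested is made for them only; others in the source may bear on it.

Measured compounds:
- compound 1: `Cc1ccc(-c2ccnc(C(=O)Nc3ccc(Oc4ccnc5[nH]ccc45)cc3)n2)cc1` — 6410 nM
- compound 2: `COc1ccc(-c2cc(C(=O)Nc3ccc(Oc4ccnc5[nH]ccc45)cc3)ncn2)cc1` — 4450 nM

Both compounds share the same amide-linked core and differ in the pyrimidine and its aryl substituent. In a functional assay on MCF7 cells (Homo sapiens) for cytotoxicity, read by MTT assay, with a stated time of 72 h (a higher number here means a weaker inhibitor, a lower number a stronger inhibitor), compound 2 gives 4450 nM, the lower of the two numbers; compound 1 gives 6410 nM, and the two values lie within the scatter of each other, so no order between them can be claimed.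

The next compound, compound 3 `O=C(Nc1ccc(Oc2ccnc3[nH]ccc23)cc1)c1cc(-c2ccccc2)ncn1`, differs from compound 2 in one place: hydrogen in place of methoxy on an aromatic carbon — hydrogen in place of methoxy on an aromatic carbon, para to a large group; cut one bond further out, the change reads 4-methoxyphenyl to phenyl. For the measured compounds named here, no step of this kind has been measured, so the expectation rests only on the two numbers above, which show no movement beyond the scatter between the two measured aryl groups. A step from compound 2 to compound 3 of about a 1.2-fold higher number from compound 2 to compound 3 (0.09 log units; within the scatter) is expected, that is, no change beyond the scatter, with a slight lean toward a higher number. Compound 3 is estimated at 5500 nM, with a range of 2500 nM to 12000 nM.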

Compound 3, half-maximal inhibitory concentration: 20 nM
Compound 3: the middle estimate sits 280-fold (2.44 log units) above what was measured; measured number outside the range, below it.
By their numbers in this assay, from the lowest: compound 3; then compounds 2 and 1 (each within the scatter of the next).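

In this assay, hydrogen in place of methoxy on the aromatic carbon gives a 220-fold lower number from compound 2 to compound 3 (2.35 log units; beyond the scatter), so this single position, para to a large group, is highly sensitive to its substituent in a way that compounds 1 and 2 could not show, since they differ in more than one place. Within this matched pair, the 4-methoxyphenyl of compound 2 is far from a silent substituent: the loss of a group of two heavy atoms and one hydrogen-bond acceptor is enough to move the number by this large step, and the phenyl of compound 3 is the better of the two. No measurement here bears on the origin of the step, so it stands as an observation only.

From the compounds shown here alone, whether the step is specific to methoxy or would also appear with fluorine, hydroxyl or an amine at this position remains open. Also open, going by these compounds, is whether the same change would give a step of similar size on the core of compound 1, whose methyl-bearing aryl cannot be read against compound 3 in a single change.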